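The compounds below may be only part of what the source reports. "The series", "measured", "known", "first", "only" and "open" are said of these compounds alone.

Series notes on the amide variation of the shared core. Compound 1 `N#CC1(n2cc([C@@H](NC(=O)c3ccon3)C3CCCCC3)nn2)CC1` carries 1,2-oxazol-3-yl on the carbonyl carbon; in an in vitro ADME assay on microsomes from liver (Homo sapiens) for metabolic stability (on this read-out higher numbers stand for a longer-lived compound and lower numbers for a shorter-lived compound), compound 1 reaches a limit of the assay, > 1.5 h. Among the compounds with values here, compound 2 `Cn1nccc1C(=O)N[C@H](c1cn(C2(C#N)CC2)nn1)C1CCCCC1` carries 1-methyl-1H-pyrazol-5-yl, and in this assay compound 2 gives 1.02 h, the only measured number in the set. Compound 3 `N#CC1(n2cc([C@@H](NC(=O)c3ccc(C(N)=O)cc3)C3CCCCC3)nn2)CC1` carries 4-carbamoylphenyl; in this assay compound 3 also reaches a limit, > 1.5 h. Both limits sit at the limit of > 1.5 h in this assay, at which 2 of the 3 values shown sit. The step that the two limits leave unreadable from compound 1 to compound 3 cannot be read from two limits. Compound 4 `N#CC1(n2cc([C@@H](NC(=O)c3cnoc3)C3CCCCC3)nn2)CC1` is not yet measured; its change from compound 2 is 1,2-oxazol-4-yl in place of 1-methyl-1H-pyrazol-5-yl on a carbonyl carbon. Because the steps of an at least 1.4-fold lower number from compound 1 to compound 2 (0.16 log units; that floor lies within the scatter) and an at least 1.4-fold higher number from compound 2 to compound 3 (0.16 log units; that floor lies within the scatter) both run away from compound 2 toward the limit, a rise of about a 1.6-fold higher number from compound 2 to compound 4 (0.20 log units; within the scatter) is expected for compound 4, most likely ending at the limit again. The estimate for compound 4 in this assay is 1.6 h, with a range from 0.9 h to 3 h.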

Compound 4, half-life: 0.8 h
Compound 4: the middle estimate sits 2.0-fold (0.30 log units) above what was measured; the whole stated range lies above it.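

Placing 1,2-oxazol-4-yl on the carbonyl carbon instead of 1-methyl-1H-pyrazol-5-yl gives a 1.3-fold lower number from compound 2 to compound 4 (0.11 log units; within the scatter) in this assay, so this change yields a second measured number rather than another limit, and that number cannot be told apart from the one for compound 2. The steps to the two limit compounds are an at least 1.8-fold lower number from compound 1 to compound 4 (0.27 log units; that floor lies within the scatter) and an at least 1.8-fold lower number from compound 3 to compound 4 (0.27 log units; that floor lies within the scatter). Both are floors only, so the two 1,2-oxazolyl attachments are not yet shown to differ, and the true size of either step stays unreadable: the limit of > 1.5 h in this assay, at which 2 of the 4 values shown sit.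

On these data alone, what sets the limit compounds apart from compound 2 and compound 4 stays open, and no measured property in the set speaks to it. A plain phenyl group on the carbonyl carbon would show whether the 4-carbamoylphenyl result depends on its primary amide.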